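The compounds below may be only part of what the source reports. "The series", "measured", "known", "first", "only" and "open" are said of these compounds alone.

In a functional assay on HeLa cells (Homo sapiens) for antiproliferative activity, read by MTT assay, with a stated time of 3 days (on this read-out lower numbers stand for stronger inhibition and higher numbers for weaker inhibition), compound 2 `CCCCCc1ccc(C#Cc2cn(C/C=C/CN3C(=O)c4ccccc4C3=O)c(=O)[nH]c2=O)cc1` gives 27000 nM and compound 3 `CCCCC#Cc1cn(C/C=C\CN2C(=O)c3ccccc3C2=O)c(=O)[nH]c1=O` gives 33000 nM, two values within the scatter of each other. Compound 1 `CCCCCc1ccc(C#Cc2cn(C/C=C\CN3C(=O)c4ccccc4C3=O)c(=O)[nH]c2=O)cc1` reads > 100000 nM, which is a limit of the assay. Compound 4 `O=C1c2ccccc2C(=O)N1C/C=C/Cn1cc(C#CCCc2ccccc2)c(=O)[nH]c1=O` differs from compound 2 by phenethyl in place of 4-pentylphenyl on a triple-bonded carbon, with phenethyl in place of 4-pentylphenyl on a triple-bonded carbon. Going by the values given here, the nearest precedent is an at least 3.0-fold lower number from compound 1 to compound 3 (0.48 log units; beyond the scatter), where butyl replaces 4-pentylphenyl at that same place, although its size rests on a limit. The other step, an at least 3.7-fold lower number from compound 1 to compound 2 (0.56 log units; beyond the scatter), comes with the fact that compounds 1 and 2 differ only in the configuration as drawn, and compound 4 keeps the double bond of compound 2. Compound 2 already stands level with compound 3, so no step beyond the scatter is expected, only a 1.2-fold lower number from compound 2 to compound 4 (0.07 log units; within the scatter). The estimate for compound 4 is 23000 nM, with an expected range of 8000 nM to 70000 nM.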

Compound 4, half-maximal inhibitory concentration: 29000 nM
Compound 4: the middle estimate sits 1.3-fold (0.10 log units) below what was measured; low and high end bracket the measured number.
By their numbers in this assay, from the lowest: compounds 2, 4 and 3 (each within the scatter of the next). At a limit, above all of these: compound 1.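

In this assay the swap of 4-pentylphenyl for phenethyl on a triple-bonded carbon gives a 1.1-fold higher number from compound 2 to compound 4 (0.03 log units; within the scatter) and so leaves no difference to read, although phenethyl has fewer heavy atoms than 4-pentylphenyl. Going by these compounds alone, this is the first change at this place with a real number at both ends. The earlier change there started from compound 1, whose value is a limit: the limit of > 100000 nM in this assay, at which 1 of the 4 values shown sits. From the compounds shown here alone, whether an amine, a carboxylic acid or a longer chain on that triple-bonded carbon would shift the number stays open. So does whether phenethyl would read the same with the double bond drawn Z.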